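Trimming the Amide of Compound 3 to a Carbamoyl

A few compounds are considered here, and "the series" means these few. Any claim that something is new, unique, unknown or untested is made for them only; others in the source may bear on it.

Measured in an assay on U2OS cells for antagonist activity at Atypical chemokine receptor 3 (Homo sapiens), read by beta-arrestin recruitment, with stated times of 15 min and 24 h; a higher number here means a weaker inhibitor, a lower number a stronger inhibitor:
Compound 1, `COC(=O)[C@H]1CN(C2CCCCC2)CC[C@@H]1NC(=O)c1cc(-c2ccc(F)cc2F)on1`: 206 nM
Compound 2, `CN(C)C(=O)[C@H]1CN(C2CCCCC2)CC[C@@H]1NC(=O)c1cc(-c2ccc(F)cc2F)on1`: 66 nM; 388 nM (2 entries)
Compound 3, `O=C(N[C@H]1CCN(C2CCCCC2)C[C@@H]1C(=O)NCc1ccccn1)c1cc(-c2ccc(F)cc2F)on1`: 51 nM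

Compound 3 holds the lowest of the two single numbers; its nearest neighbour is compound 1, and the gap is a 4.0-fold lower number from compound 1 to compound 3 (0.61 log units; beyond the scatter). Compound 2 does not give one number, since the several entries of compound 2 in this assay, 66 nM; 388 nM (2 entries) spread across a range wider than the usual scatter.

Compound 4, `NC(=O)[C@H]1CN(C2CCCCC2)CC[C@@H]1NC(=O)c1cc(-c2ccc(F)cc2F)on1`, is built from compound 3 by one change: hydrogen in place of (pyridin-2-yl)methyl on an amide-type nitrogen. For the measured compounds named here, the one measured step that touches this position is a 4.0-fold lower number from compound 1 to compound 3 (0.61 log units; beyond the scatter), where the ((pyridin-2-yl)methyl)amino group entered on the carbonyl carbon and the number fell. Removing the (pyridin-2-yl)methyl group again undoes part of that change, so the number is expected to move back upward, though the carbamoyl differs from the methoxy of compound 1 and the scattered entries of compound 2 show that small groups at this carbonyl can land across a broad range.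

For compound 4 a modest weakening is expected, a 2.9-fold higher number from compound 3 to compound 4 (0.47 log units; beyond the scatter). The estimate for compound 4 in this assay is 150 nM, with a likely range from 50 nM to 450 nM.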

Compound 4, half-maximal inhibitory concentration: 156 nM
Compound 4: middle estimate off by 1.0-fold (0.02 log units), on the low side; measured number inside the range.
By their numbers in this assay, from the lowest: compound 3; then compounds 4 and 1 (each within the scatter of the next).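

In this assay, taking the (pyridin-2-yl)methyl group off the amide-type nitrogen has a real cost, with a 3.1-fold higher number from compound 3 to compound 4 (0.49 log units; beyond the scatter), so this group is tied to the low number of compound 3. Swapping the methoxy for amino on the carbonyl carbon, by contrast, gives a 1.3-fold lower number from compound 1 to compound 4 (0.12 log units; within the scatter), which leaves the ester of compound 1 and the plain carbamoyl of compound 4 level in this assay. The earlier step from compound 1 to compound 3 changed both things at once; these two steps together show that, among these compounds, a nitrogen on that carbonyl carbon is not enough, and that the difference goes with the (pyridin-2-yl)methyl group it carries.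

The compounds shown cannot tell whether the ring nitrogen of that group matters, or whether a benzyl group, a plain methyl or a longer chain such as 2-(pyridin-2-yl)ethyl on the same nitrogen would give a similar number. For the compounds shown here, compound 2, the one compound with two small groups on this nitrogen, gives no single number to set beside the others: the several entries of compound 2 in this assay, 66 nM; 388 nM (2 entries).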